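This account rests on a few compounds, and the source may have more. Where it says the series, first, only, none or still open, it means among the compounds named here.

Measured so far:
- compound 1 `O=C(NCc1cccc(Cl)c1)c1ccc2cn(CCn3cccn3)nc2c1`: 173 nM
- compound 2 `COc1cc(C(=O)N2CC[C@@H](O)[C@H](C)C2)cc2nc(NCc3cccc(Cl)c3)oc12`: 10 nM
- compound 3 `COc1cc(C(=O)N2CCC(O)C(C)C2)cc2nc(NCc3cc(Cl)ccn3)oc12`: 190 nM

In an assay on isolated protein for inhibition of thyroid hormone receptor beta (Homo sapiens), read by fluorescence, with a stated time of 30 min (a higher number here means a weaker inhibitor, a lower number a stronger inhibitor), compound 3 gives the highest of the three numbers. Compound 1, built on a different core, gives 173 nM, which lies within the scatter of compound 3. On the shared core, compound 2 gives 10 nM, a gap that is well beyond the scatter. Compound 4 `COc1cc(C(=O)N2CCC(O)C(C)C2)cc2nc(N[C@H](C)c3cccc(Cl)c3)oc12` differs from compound 3 in one place: 1-(3-chlorophenyl)ethyl in place of (4-chloropyridin-2-yl)methyl on a nitrogen on an aromatic ring. A sizeable drop in the number is expected, because compound 2 gives 10 nM on the same core with an amine substituent built on a chlorophenyl ring rather than a chloropyridine. Compound 4 is therefore estimated at 25 nM, within a range of 5 nM to 120 nM, an expected step of a 7.6-fold lower number from compound 3 to compound 4 (0.88 log units; beyond the scatter).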

Compound 4, half-maximal inhibitory concentration: 48 nM
The estimate for compound 4 lay 1.9-fold (0.28 log units) below the measured number, within the range that was stated.
By their numbers in this assay, from the lowest: compound 2; then compound 4; then compounds 1 and 3 (each within the scatter of the next).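

In this assay the change on this nitrogen gives a 4.0-fold lower number from compound 3 to compound 4 (0.60 log units; beyond the scatter) and so shows that the number responds to the group placed here. The swap alters the ring and brings in a defined stereocentre at once, so the step cannot be divided between the two. Nothing measured here explains the step. A 1-(4-chloropyridin-2-yl)ethyl group on this nitrogen would separate the ring change from the added methyl branch. The mirror-image form of 1-(3-chlorophenyl)ethyl would test whether the stereocentre matters.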